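Extending the Sulfonamide Series to a Pyrimidinyl Analogue

The source may hold more compounds than are shown below. What is called first, only, known or untested is meant among the compounds shown, and "the series" means these compounds.

Of the compounds shown here, three that share one core have been tested in a functional assay on B16-F10 cells (Mus musculus) for cytotoxicity, read by CCK-8 assay, with a stated time of 48 h; a higher number here means a weaker inhibitor, a lower number a stronger inhibitor. Compound 1 `Cc1ccc2oc(=O)c(/C=N/c3ccc(S(N)(=O)=O)cc3)c(Cl)c2c1` gives 360 nM, compound 2 `Cc1ccc2oc(=O)c(/C=N/c3ccc(S(=O)(=O)Nc4nccs4)cc3)c(Cl)c2c1` gives 280 nM, and compound 3 `Cc1ccc2oc(=O)c(/C=N/c3ccc(S(=O)(=O)NC(=N)N)cc3)c(Cl)c2c1` gives 240 nM. Compound 3 stands close to both of its neighbours: a 1.5-fold lower number from compound 1 to compound 3 (0.18 log units; within the scatter) and a 1.2-fold lower number from compound 2 to compound 3 (0.07 log units; within the scatter). Compound 4 `Cc1ccc2oc(=O)c(/C=N/c3ccc(S(=O)(=O)Nc4nc(C)cc(C)n4)cc3)c(Cl)c2c1` carries a group of 8 heavy atoms (6 carbon, 2 nitrogen; one six-membered aromatic ring with 2 hetero atoms) in place of a group of 3 heavy atoms (1 carbon, 2 nitrogen; no ring), on a sulfonamide nitrogen. Going by the values given here, the steps that bear on this change are a 1.3-fold lower number from compound 1 to compound 2 (0.11 log units; within the scatter) and a 1.2-fold lower number from compound 2 to compound 3 (0.07 log units; within the scatter), both small, so a further substituent on the same sulfonamide nitrogen is expected to move this assay by no more than the scatter, in no particular direction. Compound 4 is therefore estimated at 250 nM, with a range from 120 nM to 520 nM. For compound 4 this means an expected step of a 1.0-fold higher number from compound 3 to compound 4 (0.02 log units; within the scatter).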

Compound 4, half-maximal inhibitory concentration: 300 nM
Beside the measured number, compound 4's estimate is 1.2-fold (0.08 log units) below it; the range from low to high includes it.
By their numbers in this assay, from the lowest: compounds 3, 2, 4 and 1 (each within the scatter of the next).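

On the sulfonamide nitrogen in this assay, 4,6-dimethylpyrimidin-2-yl gives a 1.3-fold higher number from compound 3 to compound 4 (0.10 log units; within the scatter) and a 1.1-fold higher number from compound 2 to compound 4 (0.03 log units; within the scatter) and also a 1.2-fold lower number from compound 1 to compound 4 (0.08 log units; within the scatter) on the way from the unsubstituted sulfonamide. A six-membered aromatic ring with no hydrogen-bond donors therefore stays in the same narrow band as hydrogen, 1,3-thiazol-2-yl and the open group of compound 3, so no change at this position among these four compounds has gone beyond the scatter. No measurement shown here offers an explanation for this flat result.
From the compounds shown here alone, whether a carboxylic acid, an amine or a longer chain on this nitrogen would move the number beyond the scatter remains open. So does the effect of any change on the shared core.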